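The compounds below may be only part of what the source reports. "The series", "measured", "known", "first", "only" and "open" are said of these compounds alone.

Measured compounds in an assay on CHO cells for displacement of a labelled ligand from adenosine receptor A3 (Homo sapiens), read by scintillation counting, with a stated time of 60 min; a higher number here means a weaker inhibitor, a lower number a stronger inhibitor:
compound 1 `CNC(=O)[C@@]12C[C@@H]1[C@@H](n1cnc3c(NC)nc(C#Cc4ccccc4OC)nc31)[C@H](O)[C@@H]2O` gives 0.77 nM
compound 2 `CNC(=O)[C@@]12C[C@@H]1[C@@H](n1cnc3c(NC)nc(C#Cc4cccnc4)nc31)[C@H](O)[C@@H]2O` gives 2.15 nM
compound 3 `CNC(=O)[C@@]12C[C@@H]1[C@@H](n1cnc3c(NC)nc(C#Cc4cnn(C)c4)nc31)[C@H](O)[C@@H]2O` gives 2.34 nM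

Compound 1 has the lowest number of the three. Its nearest neighbour is compound 2, reached by a 2.8-fold higher number from compound 1 to compound 2 (0.45 log units; beyond the scatter), and the furthest is compound 3, reached by a 3.0-fold higher number from compound 1 to compound 3 (0.48 log units; beyond the scatter); compound 2 and compound 3 themselves differ by only a 1.1-fold higher number from compound 2 to compound 3 (0.04 log units; within the scatter).

Compound 4 `CNC(=O)[C@@]12C[C@@H]1[C@@H](n1cnc3c(NC)nc(C#Cc4nccs4)nc31)[C@H](O)[C@@H]2O` is not yet measured. It differs from compound 1 in one place: 1,3-thiazol-2-yl in place of 2-methoxyphenyl on a triple-bonded carbon. The two measured steps that bear on this are those from compound 1 to compound 2 and from compound 1 to compound 3, both of which also replace 2-methoxyphenyl on the triple-bonded carbon with a smaller ring bearing hetero atoms, and both of which gave a modest rise in the number, beyond the scatter but of similar size to each other. On that basis compound 4 is expected to sit a modest step above compound 1, a 3.0-fold higher number from compound 1 to compound 4 (0.48 log units; beyond the scatter), and its estimated value in this assay is 2.3 nM, within a range of 1 nM to 6 nM.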

Compound 4, inhibition constant: 2.1 nM
Compound 4: the middle estimate sits 1.1-fold (0.04 log units) above what was measured; the measured number falls inside the stated range.
By their numbers in this assay, from the lowest: compound 1; then compounds 4, 2 and 3 (each within the scatter of the next).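

On a triple-bonded carbon in this assay, 1,3-thiazol-2-yl in place of 2-methoxyphenyl gives a 2.7-fold higher number from compound 1 to compound 4 (0.44 log units; beyond the scatter) as a third modest step, and this time the entering ring contains sulfur. The pyridin-3-yl and 1-methyl-1H-pyrazol-4-yl groups cannot be told apart from it, as shown by a 1.1-fold lower number from compound 3 to compound 4 (0.05 log units; within the scatter) and by a 1.0-fold lower number from compound 2 to compound 4 (0.01 log units; within the scatter) together, so among these four compounds only compound 1 stands apart, and the three hetero-atom rings form one group. Nothing measured here accounts for this grouping.

As far as these compounds go, it remains open whether the lower number of compound 1 goes with its methoxy group or with the phenyl ring itself, which a plain phenyl group on the triple-bonded carbon would separate. Also open, from the compounds shown here alone, is how a ring bearing an amine or a 2-ethoxyphenyl group would stand.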